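The source may hold more compounds than are shown below. What is called first, only, known or untested is meant among the compounds shown, and "the series" means these compounds.

Measured so far:
compound 1 `N#Cc1cccc(-n2nnc(-c3ccccn3)n2)c1` — in a functional assay with metabotropic glutamate receptor 5 (Rattus norvegicus) as the target (on this read-out higher numbers stand for weaker inhibition and lower numbers for stronger inhibition), compound 1 gives 73 nM
compound 2 `N#Cc1cc(OCc2ccccc2)cc(-n2nnc(-c3ccccn3)n2)c1` — compound 2 reaches only a limit of this assay, > 1000 nM

Compound 2 thus stands at the edge of what this assay reports: its value is a limit, not a number, and it sits at the limit of > 1000 nM in this assay, at which 1 of the 2 values shown sits. For the measured compounds named here, one measured step bears on the change considered here, namely an at least 13-fold higher number from compound 1 to compound 2 (1.13 log units; beyond the scatter), a large loss on adding the benzyloxy group. Compound 3 `N#Cc1cc(Oc2cccnc2)cc(-n2nnc(-c3ccccn3)n2)c1` differs from compound 2 by pyridin-3-yl in place of benzyl on an oxygen on an aromatic ring. With compound 2 giving only a limit, the step to compound 3 has no numerical anchor; because the step of an at least 13-fold higher number from compound 1 to compound 2 (1.13 log units; beyond the scatter) was large, an oxygen-linked aromatic group is expected to keep compound 3 well away from compound 1 in this assay. Compound 3 is estimated at 800 nM in this assay, within 150 nM to 3000 nM. That is expected to mean an at least 1.2-fold lower number from compound 2 to compound 3 (0.09 log units; that floor lies within the scatter).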

Compound 3, half-maximal inhibitory concentration: 15 nM
For compound 3 the middle estimate is 53-fold (1.73 log units) above the measured one; the whole stated range lies above it.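

In this assay, adding the (pyridin-3-yl)oxy group gives a 4.9-fold lower number from compound 1 to compound 3 (0.69 log units; beyond the scatter), so the loss seen with benzyloxy does not hold for every oxygen-linked group at this position. The group on the oxygen decides the outcome: pyridin-3-yl in place of benzyl gives an at least 66-fold lower number from compound 2 to compound 3 (1.82 log units; beyond the scatter), and the size of this step is only a floor. The value of compound 2 is a limit and not a number: the limit of > 1000 nM in this assay, at which 1 of the 3 values shown sits.

Benzyl and pyridin-3-yl differ both in their heavy atoms and in the ring, carbon only against one with a hetero atom, so the compounds shown do not tell which difference carries the step, and a phenyl group on the same oxygen would separate the two. On these data alone, how pyridin-4-yl, or a pyridin-3-yl ring bearing an amine, would read also stays open.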